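The source may hold more compounds than are shown below. What is called first, only, known or untested is meant among the compounds shown, and "the series" means these compounds.

Measured so far in an ADME assay on HepG2 cells (Homo sapiens) for cytotoxicity, with a stated time of 48 h; on this read-out higher numbers stand for weaker inhibition and lower numbers for stronger inhibition:

Compound 1 `O=[N+]([O-])c1cc(-c2nnc(SCc3ccccc3)n2Cc2ccccc2)cc([N+](=O)[O-])c1`: in this assay compound 1 gives > 30000 nM, which is a limit of the assay.
Compound 2 `CSc1nnc(-c2cc([N+](=O)[O-])cc([N+](=O)[O-])c2)n1Cc1ccccc1`: in this assay compound 2 gives > 30000 nM, a limit.
Compound 3 `O=[N+]([O-])c1cc(-c2nnc(SCc3ccc(Br)cc3)n2Cc2ccccc2)cc([N+](=O)[O-])c1`: in this assay compound 3 gives > 30000 nM, again a limit.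

Compound 3 therefore stands at the assay limit rather than at a number, and so do the other two values; the limit of > 30000 nM in this assay, at which 3 of the 3 values shown sit, shows the whole set sitting there. The three measured steps, a step that the two limits leave unreadable from compound 1 to compound 2, a step that the two limits leave unreadable from compound 1 to compound 3 and a step that the two limits leave unreadable from compound 2 to compound 3, are unreadable in size because the limit of > 30000 nM in this assay, at which 3 of the 3 values shown sit, covers both ends of each.

Compound 4 `O=[N+]([O-])c1cc(-c2nnc(SCc3ccc(Cl)cc3)n2Cc2ccccc2)cc([N+](=O)[O-])c1` differs from compound 3 by chloro in place of bromo on an aromatic carbon. Within the data shown here, no measured step has a readable size, so nothing indicates a change beyond the scatter in this assay, in either direction. Compound 4 is expected to sit at the limit as well, with an estimate of 40000 nM and a range of 15000 nM to 100000 nM. That estimate means a step that the limit leaves unreadable from compound 3 to compound 4.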

Compound 4, half-maximal inhibitory concentration: > 30000 nM
Compound 4 ended at the assay's limit (the forecaster's own chance of this, stated with the estimate: 85%); the middle value lies beyond the limit too.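

No step from compound 1, compound 2 or compound 3 to compound 4 can be read, because both ends of each sit at a limit: the limit of > 30000 nM in this assay, at which 4 of the 4 values shown sit.

The compounds shown leave open which structural change, if any, would give a measurable value.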